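The source may report more compounds than this note shows. Statements on the series, on what has been measured and on what is new or still open speak of the compounds shown alone.

Compound 1, `O=C1O[C@H]([C@@H](O)Cn2cc(CCO)nn2)C(OCc2ccccc2)=C1OCc1ccccc1`, carries a hydroxyethyl substituent on its triazole and a free hydroxy group on the chain that links the triazole to the lactone core. In a functional assay on A549 cells (Homo sapiens) for antiproliferative activity, read by MTT assay, with a stated time of 72 h (on this read-out lower numbers stand for stronger inhibition and higher numbers for weaker inhibition), compound 1 is reported only as a limit, > 100000 nM. Compound 2, `COc1ccccc1-c1cn(C/C=C2\OC(=O)C(OCc3ccccc3)=C2OCc2ccccc2)nn1`, bears a methoxyphenyl substituent on the triazole and an unsaturated linker in place of the hydroxylated chain. In this assay compound 2 likewise reaches only a limit, > 100000 nM. For the measured compounds named here, compound 1 therefore stands at the edge of what this assay can report, and the limit of > 100000 nM in this assay, at which 2 of the 2 values shown sit, shows that every value so far sits there, so no measured step between compounds is available for comparison.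

Compound 3, `CCCCCCCCCCc1cn(C[C@H](O)[C@H]2OC(=O)C(OCc3ccccc3)=C2OCc2ccccc2)nn1`, is the unmeasured analogue. It differs from compound 1 by octyl in place of hydroxy on a saturated chain carbon, two bonds along the chain from an aromatic carbon. With both known values resting at the limit, the data give no measured direction for such a change, and any step from compound 1 to compound 3 would have to carry compound 3 below the limit to become a number. Compound 3 is expected to show an estimated step of an at least 1.6-fold lower number from compound 1 to compound 3 (0.22 log units; that floor lies within the scatter) in this assay. Compound 3 is thus estimated at 60000 nM, with a range from 15000 nM to 150000 nM in this assay.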

Compound 3, half-maximal inhibitory concentration: 6750 nM
For compound 3 the middle estimate is 8.9-fold (0.95 log units) above the measured one, and the stated range ends above it.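

In this assay, replacing hydroxy with octyl on a saturated chain carbon, two bonds along the chain from an aromatic carbon, gives an at least 14-fold lower number from compound 1 to compound 3 (1.17 log units; beyond the scatter), the first evidence among these compounds that this position can change the read-out. That size is only a floor: compound 1 gives > 100000 nM, which is a limit and not a number. Compound 3 is also the only compound here with a measured number, so this single change is what separates it from the limit in the series shown: the limit of > 100000 nM in this assay, at which 2 of the 3 values shown sit.

The compounds shown leave open whether the change in the read-out follows from the removal of the terminal hydroxy group, from the added carbon chain, or from both, and a plain ethyl group or a decyl chain ending in hydroxy at this position would separate those readings. They also leave open how the value moves with chain length, which a shorter butyl chain or a longer dodecyl chain would test, and whether an amine or a carboxylic acid at the end of the chain would keep the value of compound 3.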